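Trimming the chain end of compound 2 to hydroxy

The compounds below may be only part of what the source reports. "The series", "measured", "known", "first", "only" and "open" are said of these compounds alone.

Of the compounds shown here, two have been measured in a functional assay (trachea) with Cavia porcellus as the target; a lower number here means a stronger inhibitor, a higher number a weaker inhibitor. Compound 1 `CCCCCCCCn1nc(-c2cccnc2)c2ccccc2c1=O` gives 21900 nM, and compound 2 `O=c1c2ccccc2c(-c2cccnc2)nn1CCSc1nccs1` gives 10500 nM, the lower of the two numbers and so the stronger inhibitor of the pair. Compound 3 `O=c1c2ccccc2c(-c2cccnc2)nn1CCO` keeps the shared core and changes only the chain end: hydroxy in place of (1,3-thiazol-2-yl)sulfanyl on a saturated chain carbon, two bonds along the chain from an aromatic nitrogen. Hydroxy thus takes the place of (1,3-thiazol-2-yl)sulfanyl on a saturated chain carbon, two bonds along the chain from an aromatic nitrogen. Among the measured compounds shown here, only one measured step bears on this place: a 2.1-fold lower number from compound 1 to compound 2 (0.32 log units; beyond the scatter), a modest one. For the measured compounds named here, no hydroxy compound has been measured, so the guide is thin. Like the hexyl of compound 1 at 21900 nM, hydroxy brings no ring, so a modest move to a higher number is expected in this assay. The expected step is a 1.7-fold higher number from compound 2 to compound 3 (0.23 log units; within the scatter). The estimate for compound 3 is 18000 nM, with an expected range of 6000 nM to 50000 nM.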

Compound 3, half-maximal inhibitory concentration: 4570 nM
Compound 3: the middle estimate sits 3.9-fold (0.60 log units) above what was measured; measured number outside the range, below it.
By their numbers in this assay, from the lowest: compound 3; then compound 2; then compound 1.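

In this assay, the chain end does not need a ring to reach the lowest number of the series: hydroxy in place of (1,3-thiazol-2-yl)sulfanyl gives a 2.3-fold lower number from compound 2 to compound 3 (0.36 log units; beyond the scatter), and hydroxy in place of hexyl gives a 4.8-fold lower number from compound 1 to compound 3 (0.68 log units; beyond the scatter). So this place on the saturated chain carbon accepts a single oxygen-bearing group, and compound 3 is the strongest inhibitor of the three, ahead of both larger chain ends. Nothing measured here accounts for why hydroxy lowers the number.

Still open, going by these compounds, is whether an amine, a methoxy group or a carboxylic acid at the same chain end would match hydroxy. A longer chain ending in hydroxy, such as 3-hydroxypropyl, would show whether the distance from the aromatic nitrogen matters as well.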